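This account rests on a few compounds, and the source may have more. Where it says the series, first, only, none or still open, it means among the compounds named here.

Compound 3, whose structure is `O=C(O)Cn1nc(C(=O)O)cc1-c1ccc(-c2ccc(Cl)cc2Cl)cc1`, is the weaker of the two compounds with a numerical result in an assay on isolated protein for inhibition of methionine--tRNA ligase, cytoplasmic (Homo sapiens); on this read-out higher numbers stand for weaker inhibition and lower numbers for stronger inhibition: compound 3 gives 100000 nM, whereas compound 2, with structure `O=C(O)c1cc(-c2ccc(-c3ccc(Cl)cc3Cl)cc2)n(-c2ccc(Cl)cc2Cl)n1`, gives 11900 nM. Compound 1, with structure `NC(=O)c1cc(-c2ccc(-c3ccc(Cl)cc3Cl)cc2)n(-c2ccccn2)n1`, gives only a limit in this assay, > 100000 nM, so it cannot be ranked against the other two (the limit of > 100000 nM in this assay, at which 1 of the 3 values shown sits).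

Compound 4, with structure `O=C(O)c1cc(-c2ccc(-c3ccc(Cl)cc3Cl)cc2)n(-c2ccccn2)n1`, has not yet been measured in this assay. It differs from compound 3 in one place: pyridin-2-yl in place of carboxymethyl on an aromatic nitrogen.

Among the compounds with values here, one measured step bears on this change. Replacing the 2,4-dichlorophenyl on the aromatic nitrogen by carboxymethyl produced an 8.4-fold higher number from compound 2 to compound 3 (0.92 log units; beyond the scatter). The step from compound 3 to compound 4 runs the other way, putting a six-membered aromatic ring back on that nitrogen in place of the carboxymethyl, so a lower number is expected in this assay, of a size comparable to the step from compound 2 to compound 3 but probably not reaching the value of compound 2, since pyridin-2-yl is not the same group as 2,4-dichlorophenyl.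

Compound 4 is therefore estimated at 25000 nM in this assay, with a plausible range from 8000 nM to 80000 nM, which corresponds to an expected step of a 4.0-fold lower number from compound 3 to compound 4 (0.60 log units; beyond the scatter).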

Compound 4, half-maximal inhibitory concentration: > 100000 nM
Compound 4: no number, only a limit; the forecaster's own chance of this, stated with the estimate: 20%; middle value at least 4.0-fold (0.60 log units) from the limit.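

In this assay compound 4 gives only a limit, > 100000 nM, and it now shares that limit with compound 1: the limit of > 100000 nM in this assay, at which 2 of the 4 values shown sit.

Putting a six-membered aromatic ring on this aromatic nitrogen is therefore not enough by itself to reach the level of compound 2: pyridin-2-yl in place of 2,4-dichlorophenyl gives an at least 8.4-fold higher number from compound 2 to compound 4 (0.92 log units; beyond the scatter), so across this pair the identity of the ring on that nitrogen matters. Pyridin-2-yl in place of carboxymethyl gives a number no lower from compound 3 to compound 4 (the limit leaves the size open), so this change brings no measurable gain over carboxymethyl in this assay.

The step between compound 1 and compound 4 cannot be read, as both values are limits, and so the compounds shown say nothing about the carboxy group against the amide when pyridin-2-yl sits on the nitrogen. As far as these compounds go, it also remains open whether the difference between compound 2 and compound 4 lies with the two chlorines or with the ring nitrogen of the pyridine, which a plain phenyl or a 4-chlorophenyl on that nitrogen would help to separate.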